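The source may hold more compounds than are shown below. What is called first, only, known or untested is meant among the compounds shown, and "the series" means these compounds.

Three compounds share one core and differ in a single group on an aromatic carbon: compound 1 `CNc1ncnc2c1c(-c1ccccc1)cn2[C@@H]1O[C@H](CO)[C@@H](O)[C@H]1O` carries phenyl, compound 2 `CNc1ncnc2c1c(-c1cc3ccccc3o1)cn2[C@@H]1O[C@H](CO)[C@@H](O)[C@H]1O` carries 1-benzofuran-2-yl and compound 3 `C#Cc1cn([C@@H]2O[C@H](CO)[C@@H](O)[C@H]2O)c2ncnc(NC)c12` carries ethynyl. All three were tested in a functional assay on CEM-DNR-bulk cells (Homo sapiens), read by MTT assay, with a stated time of 72 h; on this read-out higher numbers stand for weaker inhibition and lower numbers for stronger inhibition. Compound 1 gives > 20000 nM, which is a limit and not a number. Compound 2 gives > 20000 nM, again a limit. Among the compounds with values here, compound 3 gives 18500 nM, the only true number among the three. The data show an at least 1.0-fold lower number from compound 1 to compound 3 (0.03 log units; that floor lies within the scatter) and an at least 1.0-fold lower number from compound 2 to compound 3 (0.03 log units; that floor lies within the scatter), so compound 3 cannot be ranked against the other two. They also show a step that the two limits leave unreadable from compound 1 to compound 2.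

Compound 4 `C#Cc1cn([C@@H]2O[C@H](CO)[C@@H](O)[C@H]2O)c2ncnc(C)c12` keeps the ethynyl group and changes a different place on the core: methyl in place of methylamino on an aromatic carbon. Within the data shown here, none of the measured steps touches this place, so they offer no size to carry over, and any forecast must stay loose. Compound 3 at 18500 nM leaves little measurable room towards weaker inhibition, so a lower number is the more likely outcome if a number is reported at all. The expected change is a 4.6-fold lower number from compound 3 to compound 4 (0.67 log units; beyond the scatter), and this estimate is uncertain. For compound 4 the estimated value is 4000 nM, with an expected range from 200 nM to 20000 nM.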

Compound 4, half-maximal inhibitory concentration: 160 nM
For compound 4 the middle estimate is 25-fold (1.40 log units) above the measured one, and the stated range ends above it.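

Swapping methylamino for methyl on the shared core gives a 120-fold lower number from compound 3 to compound 4 (2.06 log units; beyond the scatter) in this assay, the only step in this set with a clear size beyond the scatter. The earlier steps all changed the group at the other aromatic carbon, and they showed little since their readings sit at or close to the top of the measurable range: the limit of > 20000 nM in this assay, at which 2 of the 4 values shown sit.

This new place, on the six-membered aromatic ring with 2 nitrogen, is therefore one where exchanging a single small group moves the number far more than anything readable so far at the ethynyl place, at least while ethynyl stays in compound 4.

One pair cannot separate the possible sources of this step, since leaving methylamino removes 1 hydrogen-bond donor, 1 hydrogen-bond acceptor and a nitrogen all at once, and the compounds shown do not tell how an unsubstituted amino group, a methoxy group or an ethyl chain would compare at this place. They also leave open whether methyl would give a similar step with phenyl or 1-benzofuran-2-yl in place of ethynyl.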